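From 4-(methylsulfanyl)phenyl to 2-chlorophenyl: what to expect

This account rests on a few compounds, and the source may have more. Where it says the series, first, only, none or still open, it means among the compounds named here.

Measured in an ADME assay on MT4 cells (Homo sapiens) for cytotoxicity, read by MTT assay, with a stated time of 4 days (on this read-out lower numbers stand for higher toxicity in this test and higher numbers for lower toxicity in this test), so far:
- compound 1 `O=C(COc1cccc2ccccc12)N/N=C/c1cccc(O)c1`: 32.6 ug/mL
- compound 2 `O=C(COc1cccc2ccccc12)N/N=C/c1ccccc1O`: 5.19 ug/mL
- compound 3 `CSc1ccc(/C=N/NC(=O)COc2cccc3ccccc23)cc1`: 68.3 ug/mL

Compound 3 gives 68.3 ug/mL as the highest of these three numbers, which makes it the least toxic of the set in this test. The next structure, compound 4 `O=C(COc1cccc2ccccc12)N/N=C/c1ccccc1Cl`, has not been measured. The change is 2-chlorophenyl in place of 4-(methylsulfanyl)phenyl on a carbon with a double bond to nitrogen, with 2-chlorophenyl in place of 4-(methylsulfanyl)phenyl on a carbon with a double bond to nitrogen.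

Among the measured compounds shown here, two measured steps bear on this, and both end at compound 3. The modest one is a 2.1-fold higher number from compound 1 to compound 3 (0.32 log units; beyond the scatter) and the large one is a 13-fold higher number from compound 2 to compound 3 (1.12 log units; beyond the scatter). Read backwards, each shows a lower number when 4-(methylsulfanyl)phenyl is replaced. The size depends heavily on the entering group, as a 6.3-fold lower number from compound 1 to compound 2 (0.80 log units; beyond the scatter) makes clear. For the measured compounds named here, the 2-hydroxyphenyl of compound 2 shares its numbering with 2-chlorophenyl, which hints at the larger drop, but no chlorine-bearing compound has been measured, so this hint is weak.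

A lower number of moderate size is therefore expected in this assay. The expected step is a 2.7-fold lower number from compound 3 to compound 4 (0.44 log units; beyond the scatter) and it remains uncertain. For compound 4 the estimated value is 25 ug/mL, with an expected range from 7 ug/mL to 70 ug/mL as its limits.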

Compound 4, half-maximal cytotoxic concentration: 56.2 ug/mL
The estimate for compound 4 lay 2.2-fold (0.35 log units) below the measured number, within the range that was stated.
By their numbers in this assay, from the lowest: compound 2; then compounds 1, 4 and 3 (each within the scatter of the next, the first and the last beyond it).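

In this assay, placing 2-chlorophenyl on the carbon with a double bond to nitrogen gives a 1.2-fold lower number from compound 3 to compound 4 (0.08 log units; within the scatter), so the two groups cannot be told apart here, and a group named with a 2 does not by itself bring the low number seen for compound 2. The clearest comparison is chloro in place of hydroxy on an aromatic carbon, which gives an 11-fold higher number from compound 2 to compound 4 (1.03 log units; beyond the scatter) and ties that low number to the 2-hydroxyphenyl group rather than to the numbering alone. Compound 1 goes against any rule based on hydroxy alone: it also carries this group, as 3-hydroxyphenyl, yet the change to 2-chlorophenyl gives a 1.7-fold higher number from compound 1 to compound 4 (0.24 log units; within the scatter), so among these four compounds only the 2-hydroxyphenyl group stands apart.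

Nothing available here explains why this one group stands apart.

On these data alone, it remains open whether a 2-aminophenyl or 2-methoxyphenyl group would follow the 2-hydroxyphenyl group or the 2-chlorophenyl group, and whether a carboxylic acid on the phenyl ring would shift the number at all.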